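Swapping a dihalophenyl for an ethylphenyl on the sulfonamide

This account rests on a few compounds, and the source may have more. Where it says the series, first, only, none or still open, it means among the compounds named here.

Of the compounds shown here, three sharing one core have been measured in a functional assay on DLD-1 cells (Homo sapiens) for antiproliferative activity, read by CellTiter-Glo, with a stated time of 72 h; on this read-out lower numbers stand for stronger inhibition and higher numbers for weaker inhibition. Compound 1 `CC1CCN(C2CCN(S(=O)(=O)c3cnc(Cl)s3)CC2)CC1` gives 1800 nM. Compound 2 `CC1CCN(C2CCN(S(=O)(=O)c3ccc(-c4ccc(Cl)cc4)cc3)CC2)CC1` gives 105 nM. Compound 3 `CC1CCN(C2CCN(S(=O)(=O)c3ccc(Br)c(Cl)c3)CC2)CC1` gives 12 nM, the lowest number of the three and therefore the strongest inhibitor in this set, with its gaps to both compound 1 and compound 2 beyond the scatter.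

Compound 4 `CCc1ccc(S(=O)(=O)N2CCC(N3CCC(C)CC3)CC2)cc1` is the next compound, not yet measured. It differs from compound 3 in one place: 4-ethylphenyl in place of 4-bromo-3-chlorophenyl on a sulfonyl sulfur. Going by the values given here, only one measured step changes the same position, the step of a 150-fold lower number from compound 1 to compound 3 (2.18 log units; beyond the scatter), and that step compares a thiazole with a halogenated phenyl rather than two phenyl rings. Compound 2 also carries a phenyl ring at this position, but with a different substituent, and its value sits well above that of compound 3. Among the compounds with values here, no measured step in this set replaces two halogens with an ethyl group, so the guidance is indirect.

On that basis compound 4 is expected to be a somewhat weaker inhibitor than compound 3, with a step of a 5.0-fold higher number from compound 3 to compound 4 (0.70 log units; beyond the scatter) in this assay. Compound 4 is estimated at 60 nM, with a plausible range from 15 nM to 250 nM.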

Compound 4, half-maximal inhibitory concentration: > 5000 nM
Compound 4 ended at the assay's limit; the forecaster's own chance of this, stated with the estimate: 2%; middle value at least 83-fold (1.92 log units) from the limit.
By their numbers in this assay, from the lowest: compound 3; then compound 2; then compound 1. At a limit, above all of these: compound 4.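

In this assay compound 4 sits at a limit of the assay, not at a number: the limit of > 5000 nM in this assay, at which 1 of the 4 values shown sits. Going by these compounds alone, the earlier compounds showed only that a halogenated phenyl ring beats a thiazole, whereas here two rings with the same count of heavy atoms and no charge, donors or acceptors are compared, and 4-ethylphenyl in place of 4-bromo-3-chlorophenyl on the sulfonyl sulfur gives an at least 410-fold higher number from compound 3 to compound 4 (2.61 log units; beyond the scatter). A phenyl ring alone is therefore not enough at this position, and what it carries decides the outcome, as the other two comparisons also show: an at least 47-fold higher number from compound 2 to compound 4 (1.67 log units; beyond the scatter), and even the weakest earlier compound gives an at least 2.7-fold higher number from compound 1 to compound 4 (0.44 log units; beyond the scatter).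

The compounds shown do not separate the two halogens of compound 3, so a phenyl ring carrying only the bromine or only the chlorine would be needed to tell which one matters. Going by these compounds, it also stays open whether any non-halogen group, such as a methoxy or a nitrile, can stand on this ring and keep the activity, or whether the loss is particular to ethyl.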